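Moving the methoxy groups on the chalcone phenyl ring

The source may report more compounds than this note shows. Statements on the series, on what has been measured and on what is new or still open speak of the compounds shown alone.

Three measured compounds share one core and differ only in the aryl group attached to the carbonyl carbon. Compound 1 `O=C(/C=C/c1cn(-c2ccccc2)nc1-c1cccnc1)c1ccccc1` carries a plain phenyl there, and in a functional assay on Huh-7 cells (Homo sapiens) for inhibition, read by sulforhodamine B assay, with a stated time of 72 h (a lower number here means a stronger inhibitor, a higher number a weaker inhibitor), compound 1 gives 2300 nM. Compound 2 `COc1ccc(C(=O)/C=C/c2cn(-c3ccccc3)nc2-c2cccnc2)cc1OC` carries a 3,4-dimethoxyphenyl, and in this assay compound 2 gives 3100 nM. Compound 3 `COc1ccc(OC)c(C(=O)/C=C/c2cn(-c3ccccc3)nc2-c2cccnc2)c1` carries a 2,5-dimethoxyphenyl, and in this assay compound 3 gives 1300 nM, the lowest of the three numbers; its gap to compound 1 is within the scatter, while the step of a 2.4-fold lower number from compound 2 to compound 3 (0.38 log units; beyond the scatter) is modest but beyond it.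

Compound 4 `COc1ccc(C(=O)/C=C/c2cn(-c3ccccc3)nc2-c2cccnc2)c(OC)c1` is the next variation: 2,4-dimethoxyphenyl in place of 2,5-dimethoxyphenyl on a carbonyl carbon. The measured steps that bear on this change are small. Among the compounds with values here, the step of a 1.8-fold lower number from compound 1 to compound 3 (0.25 log units; within the scatter) and the step of a 1.3-fold higher number from compound 1 to compound 2 (0.13 log units; within the scatter) both stay within the scatter, and only the step of a 2.4-fold lower number from compound 2 to compound 3 (0.38 log units; beyond the scatter) reaches a modest size. Rearranging the two methoxy groups on this ring has therefore shifted the number little so far, and a similar rearrangement is expected to do the same. Compound 4 is expected to give roughly 2000 nM in this assay, within a range from 900 nM to 4500 nM, which amounts to an expected step of a 1.5-fold higher number from compound 3 to compound 4 (0.19 log units; within the scatter).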

Compound 4, half-maximal inhibitory concentration: 2400 nM
The estimate for compound 4 lay 1.2-fold (0.08 log units) below the measured number; measured number inside the range.
By their numbers in this assay, from the lowest: compounds 3, 1, 4 and 2 (each within the scatter of the next, the first and the last beyond it).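

In this assay, moving one methoxy group to give the 2,4-dimethoxyphenyl stays within the scatter (a 1.8-fold higher number from compound 3 to compound 4 (0.27 log units; within the scatter)), and so does the comparison with the 3,4-dimethoxyphenyl (a 1.3-fold lower number from compound 2 to compound 4 (0.11 log units; within the scatter)). The comparison with the plain phenyl is the new piece of information: compound 4 and compound 1 cannot be told apart (a 1.0-fold higher number from compound 1 to compound 4 (0.02 log units; within the scatter)), so this pair of methoxy groups on the ring attached to the carbonyl carbon gives a number that matches the ring with no methoxy groups at all. Within the data shown here, compound 2 and compound 3 remain the only pair separated by more than the scatter, and because compound 4 lies within the scatter of both, it does not extend that modest gap into a clear ranking of the methoxy arrangements.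

Nothing available here explains the gap between compound 2 and compound 3. Still open, on these data alone, is whether an amine or a carboxylic acid on this ring, in place of a methoxy group, would move the number by more than the scatter, and whether changes elsewhere on the shared core would matter more than changes at this ring.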